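Dibutylamino in place of 4-methylpiperazin-1-yl on a shared core

The source may report more compounds than this note shows. Statements on the series, on what has been measured and on what is new or still open speak of the compounds shown alone.

In a functional assay on MCF7 cells (Homo sapiens) for antiproliferative activity, read by MTT assay, with a stated time of 48 h (on this read-out higher numbers stand for weaker inhibition and lower numbers for stronger inhibition), compound 1 `Oc1ccc2cc1Oc1ccc(cc1)CCc1ccc(CN3CCCC3)c(O)c1-c1ccc(cc1O)CC2` gives 2410 nM, compound 2 `Oc1ccc2cc1Oc1ccc(cc1)CCc1ccc(CN3CCCCC3)c(O)c1-c1ccc(cc1O)CC2` gives 5070 nM and compound 3 `CN1CCN(Cc2ccc3c(c2O)-c2ccc(cc2O)CCc2ccc(O)c(c2)Oc2ccc(cc2)CC3)CC1` gives 6020 nM. All three share one core and differ only in the amine on a saturated chain carbon bound to an aromatic carbon. Compound 3 stands at the upper end of these numbers together with compound 2, since a 1.2-fold higher number from compound 2 to compound 3 (0.07 log units; within the scatter) lies within the scatter. Compound 1 sits apart from both: a 2.5-fold higher number from compound 1 to compound 3 (0.40 log units; beyond the scatter) and a 2.1-fold higher number from compound 1 to compound 2 (0.32 log units; beyond the scatter) are modest steps beyond the scatter.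

Compound 4 `CCCCN(CCCC)Cc1ccc2c(c1O)-c1ccc(cc1O)CCc1ccc(O)c(c1)Oc1ccc(cc1)CC2` keeps the shared core but carries dibutylamino in place of 4-methylpiperazin-1-yl on a saturated chain carbon bound to an aromatic carbon. Dibutylamino has no ring, unlike the three measured amines, so no measured step shows this kind of change directly. The nearest guide is the set of amine swaps above, the largest of which, a 2.5-fold higher number from compound 1 to compound 3 (0.40 log units; beyond the scatter), is still modest. In this assay no step beyond the scatter is therefore expected, and the data give no firm direction. The estimated change is a 1.5-fold lower number from compound 3 to compound 4 (0.18 log units; within the scatter). For compound 4 the expected value is 4000 nM, with an estimated range from 1500 nM to 10000 nM.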

Compound 4, half-maximal inhibitory concentration: > 20000 nM
Compound 4 gave a limit, no number; the forecaster's own chance of this, stated with the estimate: 5%; at least 5.0-fold (0.69 log units) between middle value and limit.
By their numbers in this assay, from the lowest: compound 1; then compounds 2 and 3 (each within the scatter of the next). At a limit, above all of these: compound 4.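

In this assay compound 4 gave a limit and no number: the limit of > 20000 nM in this assay, at which 1 of the 4 values shown sits.

Exchanges among the three ring amines on this saturated chain carbon had produced only modest steps, the largest being a 2.5-fold higher number from compound 1 to compound 3 (0.40 log units; beyond the scatter), whereas moving to the open-chain dibutylamino gives an at least 3.3-fold higher number from compound 3 to compound 4 (0.52 log units; beyond the scatter), an at least 3.9-fold higher number from compound 2 to compound 4 (0.59 log units; beyond the scatter) and an at least 8.2-fold higher number from compound 1 to compound 4 (0.91 log units; beyond the scatter). For the compounds shown here, the result therefore shows that this position does not accept every amine equally, and that the change to dibutylamino carries a cost beyond the scatter against each of the ring amines, something the earlier compounds could not show.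

Because dibutylamino is the only open-chain amine here, the compounds shown do not separate the loss of the ring from the presence of the butyl chains, and the limit leaves the true size of the step unknown. Going by these compounds, whether a shorter open-chain amine such as dimethylamino or diethylamino would stay with the ring amines or fall with compound 4 remains open, as does the place of a ring amine such as morpholin-4-yl.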